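Butyl Swapped for 4-Fluorophenyl: Expected Cytotoxicity of Compound 3

A few compounds are considered here, and "the series" means these few. Any claim that something is new, unique, unknown or untested is made for them only; others in the source may bear on it.

Compound 1 `CCCCc1cn(C(c2ccccc2)c2cc3cc(Br)ccc3nc2OC)nn1` was tested in an ADME assay on HEK293 cells (Homo sapiens) for cytotoxicity, read by sulforhodamine B assay, with a stated time of 48 h, tested at 10 uM (a higher number here means more inhibition at the concentration tested (going by the name of the read-out), a lower number less inhibition), where compound 1 gives -3.47%. Within the data shown here, its only measured neighbour, compound 2 `CCCCCCc1cn(C(c2ccccc2)c2cc3cc(Br)ccc3nc2OC)nn1`, gives -3.17% in this assay. Compound 1 thus stands lowest of the two numbers, with compound 2 nearest: the step of a number 0.3 percentage points higher from compound 1 to compound 2 (within the scatter) shows that lengthening the chain left the read-out unchanged, and both values sit at essentially no inhibition at the concentration tested.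

Compound 3 `COc1nc2ccc(Br)cc2cc1C(c1ccccc1)n1cc(-c2ccc(F)cc2)nn1` differs from compound 1 in one place: 4-fluorophenyl in place of butyl on an aromatic carbon. Among the measured compounds shown here, no measured step covers this replacement of a chain by an aromatic group; the single step on record, a chain extension, was within the scatter. Since both measured compounds show no inhibition, compound 3 is expected to behave likewise, with a step of a number 3.5 percentage points higher from compound 1 to compound 3 (within the scatter) that lies within the scatter. For compound 3 the estimate is 0%, within a range from -12% to 15%.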

Compound 3, a percentage reported as inhibition, at one concentration (the size of the read-out at that concentration, not a potency): 4.04%
Compound 3: the middle estimate sits 4 percentage points below what was measured; the range from low to high includes it.
By their numbers in this assay, from the lowest: compounds 1, 2 and 3 (each within the scatter of the next).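

The earlier compounds shown here showed only that a longer chain at this aromatic carbon of the five-membered ring leaves the read-out unmoved. Compound 3 extends that to an aromatic ring: in this assay, 4-fluorophenyl in place of butyl (a number 7.5 percentage points higher from compound 1 to compound 3 (within the scatter)) and in place of hexyl (a number 7.2 percentage points higher from compound 2 to compound 3 (within the scatter)) both stay inside the scatter, so at the concentration tested this position accepts a six-membered aromatic ring as well as a saturated chain without separating the compounds. Nothing in the data speaks to why this read-out stays so flat across these groups.

Going by these compounds, whether an amine or a carboxylic acid at this same carbon would also leave the read-out undisturbed stays open. So does whether a plain phenyl, without its fluorine, would read alike.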